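Methyl Added to the Phenyl Ring of Compound 2

This account rests on a few compounds, and the source may have more. Where it says the series, first, only, none or still open, it means among the compounds named here.

Within the data shown here, in an assay on A10 cells for binding affinity to Endothelin-1 receptor (Rattus norvegicus) (on this read-out higher numbers stand for weaker inhibition and lower numbers for stronger inhibition), compound 2 `N#Cc1ccc(OCc2ccsc2)cc1/C=C(/C(=O)O)c1ccccc1` gives 80 nM, the lowest of the two numbers known. Compound 1 `N#Cc1ccc(OCc2ccsc2)cc1/C=C(/CCC(=O)O)c1ccccc1` gives 700 nM, and the step of an 8.8-fold lower number from compound 1 to compound 2 (0.94 log units; beyond the scatter) came with carboxy in place of 2-carboxyethyl. Compound 3 `Cc1ccccc1/C(=C\c1cc(OCc2ccsc2)ccc1C#N)C(=O)O` differs from compound 2 only by methyl in place of hydrogen on an aromatic carbon, ortho to a large group. Among the measured compounds shown here, no measured step touches that position, and nothing in the two numbers points in either direction. The step of no change at the digits printed from compound 2 to compound 3 (within the scatter) is therefore expected to stay within the scatter. Compound 3 is estimated at 80 nM, between 25 nM and 250 nM.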

Compound 3, half-maximal inhibitory concentration: 300 nM
For compound 3 the middle estimate is 3.8-fold (0.57 log units) below the measured one; the whole stated range lies below it.
By their numbers in this assay, from the lowest: compound 2; then compound 3; then compound 1.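

Replacing phenyl with 2-methylphenyl gives a 3.8-fold higher number from compound 2 to compound 3 (0.57 log units; beyond the scatter) in this assay, so this aromatic carbon is not indifferent to substitution, even with a single added carbon. Among these compounds, it is the first evidence on this ring, as the earlier step changed only the acid-bearing chain. Nothing available gives a reason for this rise.

As far as these compounds go, it remains open whether ethyl, methoxy or a chlorine atom at this same carbon would shift the number further. From the compounds shown here alone, it also remains open whether methyl on another carbon of this ring would have the same effect.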